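A Fluorine-for-Methyl Swap at the Benzyl Ether

The compounds below may be only part of what the source reports. "The series", "measured", "known", "first", "only" and "open" are said of these compounds alone.

Measured in a functional assay on Mahlavu cells (Homo sapiens) for antiproliferative activity, read by sulforhodamine B assay, with a stated time of 72 h; a lower number here means a stronger inhibitor, a higher number a weaker inhibitor:
Compound 1 `Cc1ccccc1COc1ccc(-c2cc(CN3CCN(Cc4ccc(C(F)(F)F)cc4)CC3)no2)cc1` gives 6800 nM.
Compound 2 `Cc1ccc(COc2ccc(-c3cc(CN4CCN(Cc5ccc(C(F)(F)F)cc5)CC4)no3)cc2)cc1` gives 7500 nM.

Within the data shown here, compound 1 has the lower of the two numbers, but the only measured step, a 1.1-fold higher number from compound 1 to compound 2 (0.04 log units; within the scatter), lies within the scatter, so the two compounds cannot be ranked. Compound 3 `Fc1ccc(COc2ccc(-c3cc(CN4CCN(Cc5ccc(C(F)(F)F)cc5)CC4)no3)cc2)cc1` differs from compound 1 by 4-fluorophenyl in place of 2-methylphenyl on a saturated chain carbon bound to an oxygen on an aromatic ring. Among the measured compounds shown here, the single step known so far changes the same ring at the same place and stays flat, so in this assay compound 3 is expected to move by no more than the scatter: a 1.0-fold higher number from compound 1 to compound 3 (0.01 log units; within the scatter). The estimate for compound 3 is 7000 nM, with a range from 3500 nM to 14000 nM.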

Compound 3, half-maximal inhibitory concentration: 3100 nM
Compound 3: the middle estimate sits 2.3-fold (0.35 log units) above what was measured; the whole stated range lies above it.
By their numbers in this assay, from the lowest: compound 3; then compounds 1 and 2 (each within the scatter of the next).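

In this assay the group on this ring can shift the number after all. Both steps to compound 3 pass the scatter: 4-fluorophenyl in place of 2-methylphenyl (a 2.2-fold lower number from compound 1 to compound 3 (0.34 log units; beyond the scatter)) and fluoro in place of methyl on an aromatic carbon (a 2.4-fold lower number from compound 2 to compound 3 (0.38 log units; beyond the scatter)). The flat step between the two methyl compounds therefore did not mean that every change on this ring goes unnoticed, and the modest gain here belongs to fluoro.

On these data alone, whether chloro or methoxy would do the same, and whether 2-fluorophenyl would match 4-fluorophenyl, stays open. Nothing at hand explains the shift.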